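Swapping a Six-Membered Ring for a Five-Membered One

A few compounds are considered here, and "the series" means these few. Any claim that something is new, unique, unknown or untested is made for them only; others in the source may bear on it.

Among the compounds with values here, in an ADME assay on liver for metabolic stability, with Liver microsome (Homo sapiens) as the target, using microsomes (on this read-out higher numbers stand for fast clearance and lower numbers for slow clearance), compound 2 `O=C(N[C@H]1CCCC[C@@H]1O)c1cn(Cc2ccc(-c3cncnc3)cc2)c2cccnc12` gives 104 mL/min/kg, the highest of the two numbers measured so far. Compound 1 `CN(C)C(=O)CNC(=O)c1cn(Cc2ccc(-n3cccn3)cc2)c2cccnc12` gives 9.3 mL/min/kg, a gap that lies beyond the usual scatter; no single structural change connects compound 1 with compound 2. Compound 3 `Cn1ccc(-c2ccc(Cn3cc(C(=O)N[C@H]4CCCC[C@@H]4O)c4ncccc43)cc2)n1` differs from compound 2 in one place: 1-methyl-1H-pyrazol-3-yl in place of pyrimidin-5-yl on an aromatic carbon. Within the data shown here, with no comparable step among the measured compounds, the expected change is a 1.2-fold lower number from compound 2 to compound 3 (0.06 log units; within the scatter), within the scatter and in no clear direction. Compound 3 is therefore estimated at 90 mL/min/kg in this assay, ranging from 40 mL/min/kg to 200 mL/min/kg.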

Compound 3, clearance: 47 mL/min/kg
Compound 3: middle estimate off by 1.9-fold (0.28 log units), on the high side; measured number inside the range.
By their numbers in this assay, from the lowest: compound 1; then compound 3; then compound 2.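

On the six-membered aromatic ring of carbon only, para to a large group, the choice of ring changes the reading in this assay: 1-methyl-1H-pyrazol-3-yl in place of pyrimidin-5-yl gives a 2.2-fold lower number from compound 2 to compound 3 (0.34 log units; beyond the scatter). Both groups have the same counts of heavy atoms and hydrogen-bond acceptors, so those counts alone do not set the number at this position. Nothing measured here explains the shift.

Still open, as far as these compounds go, is whether a simple group at this place, such as methoxy or a morpholine ring, would move the number further, and in which direction.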